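Furan amide sulfamates: phenyl to pyridyl swap

A few compounds are considered here, and "the series" means these few. Any claim that something is new, unique, unknown or untested is made for them only; others in the source may bear on it.

Measured in an assay on T47D cells for inhibition of Steryl-sulfatase (Homo sapiens), read by HPLC, with a stated time of 24 h; a higher number here means a weaker inhibitor, a lower number a stronger inhibitor:
compound 1 `Cc1ccccc1N(C)C(=O)c1ccc(-c2cccc(OS(N)(=O)=O)c2)o1` gives 690 nM
compound 2 `Cc1ccc(F)cc1N(C)C(=O)c1ccc(-c2ccc(OS(N)(=O)=O)cc2)o1` gives 40 nM

Compound 2 carries the lowest of the two numbers in this assay; the nearest is compound 1, whose number is higher by a margin beyond the scatter. Compound 1 and compound 2 differ in more than one place, so their two values are simply noted as they stand. Compound 3 `Cc1ncccc1N(C)C(=O)c1ccc(-c2ccc(OS(N)(=O)=O)cc2)o1` is the next member. Relative to compound 2 it carries 2-methylpyridin-3-yl in place of 5-fluoro-2-methylphenyl on an amide-type nitrogen; the amide-type nitrogen otherwise keeps its carbonyl carbon and saturated chain carbon. Going by the values given here, no measured step of this kind exists, so the size of the move from compound 2 is open. The expectation is a small loss of potency at most, with the step of a 2.0-fold higher number from compound 2 to compound 3 (0.30 log units; within the scatter) not clearly beyond the scatter. Compound 3 is estimated at 80 nM with a range of 25 nM to 300 nM.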

Compound 3, half-maximal inhibitory concentration: 270 nM
Beside the measured number, compound 3's estimate is 3.4-fold (0.53 log units) below it, within the range that was stated.
By their numbers in this assay, from the lowest: compound 2; then compound 3; then compound 1.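

In this assay, going by these compounds alone, putting 2-methylpyridin-3-yl in place of 5-fluoro-2-methylphenyl on the amide-type nitrogen gives a 6.8-fold higher number from compound 2 to compound 3 (0.83 log units; beyond the scatter), the only one-place step so far. The group at this position therefore affects potency, and this aromatic swap is not a neutral exchange here. No supporting measurement accounts for the size of the step.

The swap removes the fluorine and introduces the ring nitrogen together, so the two contributions cannot be separated; 5-fluoro-2-methylpyridin-3-yl on the same nitrogen would help to divide them. Also open, from the compounds shown here alone, is how far the trend extends to other groups at this position, such as unsubstituted pyridin-3-yl or cyclohexyl.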